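One side-chain swap on compound 2

The source may hold more compounds than are shown below. What is called first, only, known or untested is meant among the compounds shown, and "the series" means these compounds.

Measured in a functional assay on Ishikawa cells (Homo sapiens) for antiproliferative activity, read by CCK-8 assay, with a stated time of 48 h; a higher number here means a weaker inhibitor, a lower number a stronger inhibitor:
- compound 1 `C=CC(=O)NCCOc1ccc(Oc2c(-c3ccc(F)cc3)sc3cc(O)ccc23)cc1`: > 25000 nM (a limit, not a number)
- compound 2 `CN(C)C(=O)/C=C/CNCCOc1ccc(Oc2c(-c3ccc(F)cc3)sc3cc(O)ccc23)cc1`: 11900 nM

Going by the values given here, compound 2, at 11900 nM, holds the only actual number in this assay. For compound 1 the reading is the limit of > 25000 nM in this assay, at which 1 of the 2 values shown sits.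

The next compound, compound 3 `C/C=C/C(=O)NCCOc1ccc(Oc2c(-c3ccc(F)cc3)sc3cc(O)ccc23)cc1`, differs from compound 2 in one place: (prop-1-en-1-yl)carbonyl in place of 3-(dimethylcarbamoyl)prop-2-en-1-yl on an amine nitrogen. Here (prop-1-en-1-yl)carbonyl stands in place of 3-(dimethylcarbamoyl)prop-2-en-1-yl on an amine nitrogen.

Among the compounds with values here, one measured step bears on this change: an at least 2.1-fold lower number from compound 1 to compound 2 (0.32 log units; beyond the scatter). That step brought in the same 3-(dimethylcarbamoyl)prop-2-en-1-yl in place of vinylcarbonyl, whereas the change to compound 3 removes it and again leaves a carbonyl group on that nitrogen. A modest move to a higher number is therefore expected, of similar size: a 2.0-fold higher number from compound 2 to compound 3 (0.30 log units; within the scatter). For compound 3 the estimated value is 24000 nM, with an expected range of 12000 nM to 48000 nM.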

Compound 3, half-maximal inhibitory concentration: 12400 nM
Beside the measured number, compound 3's estimate is 1.9-fold (0.29 log units) above it; the measured number falls inside the stated range.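

In this assay, the swap on this amine nitrogen gives a 1.0-fold higher number from compound 2 to compound 3 (0.02 log units; within the scatter), so the 3-(dimethylcarbamoyl)prop-2-en-1-yl group of compound 2 and the (prop-1-en-1-yl)carbonyl group of compound 3 cannot be told apart here. The dimethylcarbamoyl end is therefore not needed to reach this level, as compound 3 lacks it and keeps the carbonyl on that nitrogen, while prop-1-en-1-yl in place of vinyl on the carbonyl carbon gives an at least 2.0-fold lower number from compound 1 to compound 3 (0.30 log units; that floor lies within the scatter). That step is only a floor, as compound 1 is held by a limit and not a number: the limit of > 25000 nM in this assay, at which 1 of the 3 values shown sits.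

The compounds shown leave open how a saturated propyl chain on that carbonyl, with no double bond, would read in this assay. They also leave open what a dimethylamino group at the end of the (prop-1-en-1-yl)carbonyl chain would do.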